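Isopropyl to methyl on a series at the assay limit

A few compounds are considered here, and "the series" means these few. Any claim that something is new, unique, unknown or untested is made for them only; others in the source may bear on it.

compound 1 `COc1cc2c(cc1OC)CN(C(=O)CN1C(=O)S/C(=C\c3nc4ccccc4n3C(C)C)C1=O)CC2` — > 50000 nM
compound 2 `CCn1c(/C=C2\SC(=O)N(CC(=O)Nc3cc(C(C)(C)C)on3)C2=O)nc2ccccc21` — > 50000 nM
compound 3 `CCn1c(/C=C2\SC(=O)N(CC(=O)N3CCCC3)C2=O)nc2ccccc21` — > 50000 nM

All three compounds were tested in a functional assay on PC-3 cells (Homo sapiens) for inhibition, read by MTT assay, with a stated time of 48 h; on this read-out lower numbers stand for stronger inhibition and higher numbers for weaker inhibition. For compound 1 the reported value > 50000 nM is a limit of the assay, not a number. For compound 2 the value > 50000 nM is likewise a limit. For compound 3 the value > 50000 nM is a limit as well. Within the data shown here, because of the limit of > 50000 nM in this assay, at which 3 of the 3 values shown sit, the only measured step, a step that the two limits leave unreadable from compound 2 to compound 3, cannot be read, and compound 1 stands at the same limit as the other two.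

Compound 4 `COc1cc2c(cc1OC)CN(C(=O)CN1C(=O)S/C(=C\c3nc4ccccc4n3C)C1=O)CC2` differs from compound 1 by methyl in place of isopropyl on an aromatic nitrogen. Among the measured compounds shown here, none of the measured steps touches this position, and the one measured step is unreadable, so there is no guide to the size of the change. Compound 4 is therefore expected to stay at the limit, with an expected step that the limit leaves unreadable from compound 1 to compound 4 that does not rise above the scatter. The estimate for compound 4 in this assay is 60000 nM, within a range from 15000 nM to 200000 nM.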

Compound 4, half-maximal inhibitory concentration: 41100 nM
For compound 4 the middle estimate is 1.5-fold (0.16 log units) above the measured one; the range from low to high includes it.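

In this assay, among these compounds, compound 4 gives 41100 nM, the first value that is a number and not a limit. For compound 1 the value > 50000 nM is a limit of the assay. The change from 1-isopropyl-1H-benzimidazol-2-yl to 1-methyl-1H-benzimidazol-2-yl gives an at least 1.2-fold lower number from compound 1 to compound 4 (0.08 log units; that floor lies within the scatter), and how far the step reaches beyond that floor cannot be read: the limit of > 50000 nM in this assay, at which 3 of the 4 values shown sit.

The compounds shown leave open how a longer chain such as n-butyl, or an amine such as 2-aminoethyl, on this aromatic nitrogen would read. They also leave open what the group on the carbonyl carbon contributes, since the step between compound 2 and compound 3 cannot be read and neither compound carries methyl on the aromatic nitrogen.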